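Demethylation of the ring amine in the ethoxyethyl series

A few compounds are considered here, and "the series" means these few. Any claim that something is new, unique, unknown or untested is made for them only; others in the source may bear on it.

Compound 1 `CCOCCn1c(N2CCN(C)CC2)nc2ccccc21` is the reference point of this small set. In a functional assay on ileum for inhibition of histamine H1 receptor (Cavia porcellus) (on this read-out higher numbers stand for weaker inhibition and lower numbers for stronger inhibition), compound 1 gives 10 nM, the lowest number of the three measured compounds. Compound 3 `CCCCOCCn1c(N2CCN(C)CC2)nc2ccccc21` gives 38 nM in this assay, and compound 2 `CC(C)CCn1c(N2CCN(C)CC2)nc2ccccc21` gives 1400 nM. The measured steps all concern the chain on the aromatic nitrogen: a 3.8-fold higher number from compound 1 to compound 3 (0.58 log units; beyond the scatter), a 140-fold higher number from compound 1 to compound 2 (2.15 log units; beyond the scatter) and a 37-fold lower number from compound 2 to compound 3 (1.57 log units; beyond the scatter). Every one of them lies beyond the scatter, and the branched chain of compound 2 stands well apart from the two ether chains.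

Compound 4 `CCOCCn1c(N2CCNCC2)nc2ccccc21` keeps the ethoxyethyl chain of compound 1 and differs only on the ring amine: hydrogen in place of methyl on an amine nitrogen in a ring, which read one bond further out is 4-methylpiperazin-1-yl to piperazin-1-yl. Within the data shown here, no measured step touches that part of the molecule, so the three steps above give no direct guide to its size or direction. In the absence of a comparable step, the expectation is a small change, with a modest weakening held as the more likely direction: a 2.0-fold higher number from compound 1 to compound 4 (0.30 log units; within the scatter) is the expected step. Compound 4 is therefore estimated at 20 nM in this assay, within a range of 5 nM to 80 nM.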

Compound 4, half-maximal inhibitory concentration: 11 nM
Compound 4: middle estimate off by 1.8-fold (0.26 log units), on the high side, and the stated range covers the measured number.
By their numbers in this assay, from the lowest: compounds 1 and 4 (each within the scatter of the next); then compound 3; then compound 2.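

In this assay, the methyl on the amine nitrogen in the ring of compound 1 can give way to hydrogen without a change that stands out from the scatter (a 1.1-fold higher number from compound 1 to compound 4 (0.04 log units; within the scatter)). This is the first step shown at the ring amine, and it separates this position from the chain on the aromatic nitrogen, where all three earlier steps lie beyond the scatter: within the ethoxyethyl series, 4-methylpiperazin-1-yl and piperazin-1-yl cannot be told apart on this read-out. No measurement among the data offers an explanation for this result.

The ring amine step is shown only with the ethoxyethyl chain, so it remains open whether hydrogen in place of methyl would read the same way with the butoxyethyl chain of compound 3 or the isopropyl-bearing chain of compound 2. Also open, going by these compounds, is how a larger group on this nitrogen, such as an ethyl, a benzyl or a 2-hydroxyethyl chain, would read in this assay.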